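A few compounds are considered here, and "the series" means these few. Any claim that something is new, unique, unknown or untested is made for them only; others in the source may bear on it.

Measured so far:
Compound 1 `CC[C@H](NC)C(=O)N[C@@H]1C(=O)N2[C@@H](CC[C@@H]1CCN)CC[C@H]2C(=O)NC(c1ccccc1)c1ccccc1`: 31000 nM
Compound 2 `CC[C@H](NC)C(=O)N[C@@H]1C(=O)N2[C@@H](CC[C@@H]1CCNC(=O)c1ccccc1)CC[C@H]2C(=O)NC(c1ccccc1)c1ccccc1`: 32600 nM

Both compounds were tested in a functional assay on HL-60 cells (Homo sapiens) for cytotoxicity, read by MTT assay, with a stated time of 96 h; on this read-out lower numbers stand for stronger inhibition and higher numbers for weaker inhibition. For the measured compounds named here, compound 1 is the only other measured compound, and compound 2 stands within the scatter of it at 32600 nM. The next compound, compound 3 `CC[C@H](NC)C(=O)N[C@@H]1C(=O)N2[C@@H](CC[C@@H]1CCNC(=O)NCc1ccccc1)CC[C@H]2C(=O)NC(c1ccccc1)c1ccccc1`, differs from compound 2 by benzylamino in place of phenyl on a carbonyl carbon. In words, benzylamino takes the place of phenyl on a carbonyl carbon, turning benzoyl into benzylcarbamoyl.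

Going by the values given here, only one measured step bears on this change: a 1.1-fold higher number from compound 1 to compound 2 (0.02 log units; within the scatter), where benzoyl replaced hydrogen on an amine nitrogen. That step stayed within the scatter, so no step beyond the scatter is expected in this assay, and the direction is left open. The expected change is a 1.1-fold lower number from compound 2 to compound 3 (0.04 log units; within the scatter). Compound 3 is estimated at 30000 nM, with an expected range of 13000 nM to 60000 nM.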

Compound 3, half-maximal inhibitory concentration: 52200 nM
The estimate for compound 3 lay 1.7-fold (0.24 log units) below the measured number; low and high end bracket the measured number.
By their numbers in this assay, from the lowest: compounds 1, 2 and 3 (each within the scatter of the next).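

In this assay, benzylamino in place of phenyl on a carbonyl carbon, which turns benzoyl into benzylcarbamoyl, gives a 1.6-fold higher number from compound 2 to compound 3 (0.20 log units; within the scatter), so a urea-type cap built on a benzyl group reads no differently here from the benzamide. Set against the free amine, benzylcarbamoyl in place of hydrogen on the amine nitrogen gives a 1.7-fold higher number from compound 1 to compound 3 (0.23 log units; within the scatter), so now two quite different groups on this nitrogen have both stayed within the scatter of the unsubstituted compound. Nothing available here explains these numbers or links them to any property of the groups.

On these data alone, whether a sulfonyl group, a carboxylic acid or a longer chain ending in an amine on this nitrogen would move the number beyond the scatter stays open. So does whether this position matters at all in this assay.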